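This account rests on a few compounds, and the source may have more. Where it says the series, first, only, none or still open, it means among the compounds named here.

Compound 2 `N#CC1=C(N)N(c2ccccc2)C(=O)N2CCCCC(N3CCCC3)C12`, 86.9%; compound 1 `N#CC1=C(/N=C/c2ccccc2)N(c2ccccc2)C(=O)N2CCCCC(N3CCCC3)C12`, 75.9%.

Among the compounds with values here, in a functional assay on the whole organism (strain albino) for inhibition, with Rattus norvegicus as the target, read by paw edema, with stated times of 1 h and 2 h, at a dose of 20 mmol/kg by the intraperitoneal route (on this read-out higher numbers stand for more inhibition at the one dose given (going by the name of the read-out) and lower numbers for less inhibition), compound 2 stands highest of the two numbers, with compound 1 the only comparison and lower. Compound 3 `N#CC1=C(NCC(=O)N2CCCCC2)N(c2ccccc2)C(=O)N2CCCCC(N3CCCC3)C12` differs from compound 2 by ((piperidin-1-yl)carbonyl)methyl in place of hydrogen on an amine nitrogen. Within the data shown here, the single step that bears on this is a number 11 percentage points higher from compound 1 to compound 2 (beyond the scatter), in which a group of several atoms gave way to a bare nitrogen and inhibition rose. Attaching a sizable group once more is therefore expected to lower the number modestly, a step of a number 9.9 percentage points lower from compound 2 to compound 3 (within the scatter). Compound 3 is expected to give about 77%, between 64% and 90%.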

Compound 3, a percentage reported as inhibition, in the whole organism at one dose (the size of the read-out at that dose, not a potency): 46.1%
The estimate for compound 3 lay 30.9 percentage points above the measured number; measured number outside the range, below it.
By their numbers in this assay, from the lowest: compound 3; then compound 1; then compound 2.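

On the amine nitrogen, ((piperidin-1-yl)carbonyl)methyl in place of hydrogen gives a large fall in this assay (a number 40.8 percentage points lower from compound 2 to compound 3 (beyond the scatter)), so attaching a group here need not cost only a modest amount. The two groups compared at this place also differ clearly (a number 29.8 percentage points lower from compound 1 to compound 3 (beyond the scatter)), so their sizes alone do not set the number. Nothing measured here explains these drops. Still open, as far as these compounds go, is which part of the entering group matters, the carbonyl or the piperidine ring. A plain methyl or a chain ending in a carboxylic acid on this nitrogen could help to separate them.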